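Chain extension on the oxime ether of compound 1

The source may hold more compounds than are shown below. What is called first, only, known or untested is meant among the compounds shown, and "the series" means these compounds.

Measured compounds in the series:
compound 1 `Nc1ncnc(Oc2ccc(NC(=O)C3(C(=O)Nc4ccc(F)cc4)CC3)cc2F)c1/C=N/OCCO` gives 2.37
compound 2 `Nc1ncnc(Oc2ccc(NC(=O)C3(C(=O)Nc4ccc(F)cc4)CC3)cc2F)c1/C=N/OCC(=O)N1CCOCC1` gives 2.1
compound 3 `Nc1ncnc(Oc2ccc(NC(=O)C3(C(=O)Nc4ccc(F)cc4)CC3)cc2F)c1/C=N/OCc1ccccc1` gives 4.45

In a physicochemical assay for lipophilicity, using the shake flask method (on this read-out higher numbers stand for higher lipophilicity and lower numbers for lower lipophilicity), compound 1 stands second highest of the three numbers. Its nearest neighbour is compound 2: the change of a number 0.27 log units lower from compound 1 to compound 2 (within the scatter). Its furthest is compound 3: the change of a number 2.08 log units higher from compound 1 to compound 3 (beyond the scatter), and between the other two the step is a number 2.35 log units higher from compound 2 to compound 3 (beyond the scatter).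

The unmeasured compound 4 `Nc1ncnc(Oc2ccc(NC(=O)C3(C(=O)Nc4ccc(F)cc4)CC3)cc2F)c1/C=N/OCCCO` differs from compound 1 in one place: hydroxymethyl in place of hydroxy on a saturated chain carbon, two bonds along the chain from an oxygen. Read one bond further out, this is 2-hydroxyethoxy to 3-hydroxypropoxy, a saturated chain lengthened by one carbon with the hydroxy kept.

Going by the values given here, none of the measured steps exercises this kind of change; each of them swaps the terminal group for something of a different class. The steps within scatter and the large steps therefore only bracket the series and show that the terminal group on this chain moves this assay strongly when a ring is introduced, while small, polar replacements leave it near its starting point. For compound 4 a small step upward in this assay is expected, at most at the edge of the scatter, so a number 0.38 log units higher from compound 1 to compound 4 (beyond the scatter) is the estimated size. Compound 4 is estimated at 2.75, with a range from 2.4 to 3.1.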

Compound 4, partition coefficient: 2.67
For compound 4 the middle estimate is 0.08 log units above the measured one; low and high end bracket the measured number.
By their numbers in this assay, from the lowest: compounds 2, 1 and 4 (each within the scatter of the next, the first and the last beyond it); then compound 3.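

In this assay, going by these compounds alone, the change from 2-hydroxyethoxy to 3-hydroxypropoxy is the first at this position that keeps the terminal hydroxy and alters only the chain, and it reads as a number 0.30 log units higher from compound 1 to compound 4 (within the scatter), so the read-out does not separate these two chain lengths. Even so, the longer alcohol parts from the (morpholin-4-yl)carbonyl terminus, with a number 0.57 log units higher from compound 2 to compound 4 (beyond the scatter), a gap that the shorter alcohol did not open, while a number 1.78 log units lower from compound 3 to compound 4 (beyond the scatter) leaves the phenyl terminus as the only large mover among the groups shown at this position. Nothing on hand explains why the chain length or the terminal group gives these numbers.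

A single lengthening cannot show whether a further carbon, as in 4-hydroxybutoxy, would stay within the scatter of compound 4 or whether the small steps add up along the chain. Also open, from the compounds shown here alone, is where a terminal amine or a carboxylic acid on this chain would fall, whether with the alcohols and the (morpholin-4-yl)carbonyl terminus or nearer the phenyl terminus.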